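Notes on the aryl swap at the ring amine, compounds 1 to 4

The compounds below may be only part of what the source reports. "The series", "measured", "known", "first", "only" and "open" are said of these compounds alone.

Measured so far in a functional assay on A549 cells (Homo sapiens) for inhibition, read by sulforhodamine B assay; a higher number here means a weaker inhibitor, a lower number a stronger inhibitor:
compound 1 `COC(=O)CC/C(C)=C/Cc1c(OC)c(C)c2c(c1OCC#CCN1CCN(c3ccc(C)cc3)CC1)C(=O)OC2`, > 50000 nM
compound 2 `COC(=O)CC/C(C)=C/Cc1c(OC)c(C)c2c(c1OCC#CCN1CCCc3ccccc31)C(=O)OC2`, 18000 nM
compound 3 `COC(=O)CC/C(C)=C/Cc1c(OC)c(C)c2c(c1OCC#CCN1CCN(C(c3ccccc3)c3ccc(Cl)cc3)CC1)C(=O)OC2`, 29100 nM.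

The result of compound 1 is a limit of the assay, > 50000 nM; that is where it stands among the three values, as the limit of > 50000 nM in this assay, at which 1 of the 3 values shown sits, records. Compound 2 and compound 3 give measured numbers in this assay, both weak.

Compound 4 `COC(=O)CC/C(C)=C/Cc1c(OC)c(C)c2c(c1OCC#CCN1CCN(c3ccccc3OC)CC1)C(=O)OC2` is the unmeasured analogue. It differs from compound 1 by 2-methoxyphenyl in place of 4-methylphenyl on an amine nitrogen in a ring. Among the measured compounds shown here, with no measured pair differing in one place, there is no step to lean on. The change is expected to bring compound 4 into the range of the measured numbers, so the step of an at least 1.4-fold lower number from compound 1 to compound 4 (0.15 log units; that floor lies within the scatter) is expected to be modest and toward stronger inhibition. Compound 4 is estimated at 35000 nM, between 12000 nM and 100000 nM.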

Compound 4, half-maximal inhibitory concentration: > 50000 nM
Compound 4 was reported as a limit (the forecaster's own chance of this, stated with the estimate: 45%); at least 1.4-fold (0.15 log units) between middle value and limit.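

Compound 1 and compound 4 both stand as limits in this assay, so no step between them can be read: the limit of > 50000 nM in this assay, at which 2 of the 4 values shown sit.

On these data alone, how 2-methoxyphenyl and 4-methylphenyl compare on an amine nitrogen in a ring stays open in this assay.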